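Thiophene hydrazone: swapping the aniline group

The source may report more compounds than this note shows. Statements on the series, on what has been measured and on what is new or still open speak of the compounds shown alone.

Measured in a functional assay on A549 cells (Homo sapiens) for cytotoxicity, read by MTT assay, with a stated time of 72 h; on this read-out lower numbers stand for stronger inhibition and higher numbers for weaker inhibition:
Compound 1 `O=C(N/N=C/c1cccc([N+](=O)[O-])c1)N1CCc2ncnc(Nc3ccc(F)c(Cl)c3)c2C1`: 43100 nM
Compound 2 `O=C(N/N=C/c1cccs1)N1CCc2ncnc(Nc3ccc(F)c(Cl)c3)c2C1`: > 200000 nM (a limit, not a number)

All that is known of compound 2 is the limit of > 200000 nM in this assay, at which 1 of the 2 values shown sits. Its true value could lie anywhere past that limit, so any step starting from it has no exact size.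

Compound 3 `O=C(N/N=C/c1cccs1)N1CCc2ncnc(Nc3cccc(C(F)(F)F)c3)c2C1` keeps the thiophen-2-yl group of compound 2 and places 3-(trifluoromethyl)phenyl in place of 3-chloro-4-fluorophenyl on a nitrogen on an aromatic ring. Among the measured compounds shown here, the only measured step, an at least 4.6-fold higher number from compound 1 to compound 2 (0.66 log units; beyond the scatter), changed a different group, so it bears on this change only indirectly. It shows that the thiophen-2-yl compound is the weaker of the two. With nothing measured for the new group, no step beyond the scatter is expected in this assay. The expected change is an at least 1.3-fold lower number from compound 2 to compound 3 (0.12 log units; that floor lies within the scatter). Compound 3 is estimated at 150000 nM, with an expected range of 40000 nM to 300000 nM.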

Compound 3, half-maximal inhibitory concentration: 42400 nM
For compound 3 the middle estimate is 3.5-fold (0.55 log units) above the measured one; the measured number falls inside the stated range.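

With the thiophen-2-yl group held fixed, the group on the nitrogen on an aromatic ring also shifts the result in this assay: 3-(trifluoromethyl)phenyl in place of 3-chloro-4-fluorophenyl gives an at least 4.7-fold lower number from compound 2 to compound 3 (0.67 log units; beyond the scatter). Among the compounds shown here, the earlier step changed only the group on the carbon with a double bond to nitrogen, so this is the first sign that this second place responds too. Going by these compounds, the true size of the new step stays unknown because compound 2 is known only by a limit: the limit of > 200000 nM in this assay, at which 1 of the 3 values shown sits.

On these data alone, only these two groups can be compared at this place, and only alongside thiophen-2-yl, so it remains open whether the same swap would act alike with the 3-nitrophenyl group of compound 1. As far as these compounds go, it is also open what an unsubstituted phenyl ring or an amine such as morpholine would do here.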